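A Second Bromo in a Flat Series

The compounds below may be only part of what the source reports. "The series", "measured", "known", "first", "only" and "open" are said of these compounds alone.

In a functional assay on HepG2 cells (Homo sapiens) for antiproliferative activity, read by MTT assay, with a stated time of 48 h (on this read-out lower numbers stand for stronger inhibition and higher numbers for weaker inhibition), compound 1 `O=[N+]([O-])c1cc(C(F)(F)F)cc([N+](=O)[O-])c1Oc1ccccc1/C=N\OCc1ccccc1` gives 1330 nM, compound 2 `O=[N+]([O-])c1cc(C(F)(F)F)cc([N+](=O)[O-])c1Oc1ccc(Br)cc1/C=N\OCc1ccccc1` gives 1180 nM and compound 3 `O=[N+]([O-])c1cc(C(F)(F)F)cc([N+](=O)[O-])c1Oc1ccc(Br)cc1/C=N\OCc1ccc(Cl)cc1Cl` gives 1070 nM. Compound 2 therefore stands within the ordinary scatter of repeat measurements from both of the others. Compound 4 `O=[N+]([O-])c1cc(C(F)(F)F)cc([N+](=O)[O-])c1Oc1c(Br)cc(Br)cc1/C=N\OCc1ccccc1` differs from compound 2 by one change: bromo in place of hydrogen on an aromatic carbon, a bromo in place of hydrogen on an aromatic carbon. Within the data shown here, the closest precedent is the same kind of swap, a 1.1-fold lower number from compound 1 to compound 2 (0.05 log units; within the scatter). The other measured change, a 1.1-fold lower number from compound 2 to compound 3 (0.04 log units; within the scatter), is equally small. On this evidence, no step beyond the scatter is expected in this assay. The estimated step is a 1.1-fold lower number from compound 2 to compound 4 (0.05 log units; within the scatter). For compound 4, the expected value is 1050 nM, with an estimated range of 550 nM to 2000 nM.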

Compound 4, half-maximal inhibitory concentration: 1480 nM
Estimate against measurement, compound 4: 1.4-fold (0.15 log units) below, and the stated range covers the measured number.
By their numbers in this assay, from the lowest: compounds 3, 2, 1 and 4 (each within the scatter of the next).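

This ring position, ortho to a large group and meta to a bromo group, takes a second bromo in this assay without a step beyond the scatter (a 1.3-fold higher number from compound 2 to compound 4 (0.10 log units; within the scatter)). Like the first bromo, the second leaves the reading within the scatter, so neither bromo separates its pair of compounds. Nothing measured here explains this result. Still open, as far as these compounds go, is whether an amine or a carboxylic acid on this same aromatic carbon would also stay within the scatter or would produce a real step.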